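The source may hold more compounds than are shown below. What is called first, only, known or untested is meant among the compounds shown, and "the series" means these compounds.

Four compounds share one core. Compound 1 `CCc1nnc(O)n2c(C(C)(C)C)nc(C)c12` carries a tert-butyl group; compound 2 `CCc1nnc(O)n2c(C(C)CC)nc(C)c12` carries sec-butyl in its place, and compound 3 `CCc1nnc(S)n2c(C(C)CC)nc(C)c12` keeps that sec-butyl but bears a sulfanyl where the others bear hydroxy. In a functional assay for inhibition, with Homo sapiens as the target (a lower number here means a stronger inhibitor, a higher number a weaker inhibitor), compound 1 gives 26000 nM and compound 2 gives 45000 nM. Compound 3 reaches only the limit of the assay, > 48000 nM. Of the two numbers, compound 2 sits nearest to compound 1, the step being a 1.7-fold higher number from compound 1 to compound 2 (0.24 log units; within the scatter). Exchanging hydroxy for sulfanyl gave an at least 1.0-fold higher number from compound 2 to compound 3 (0.02 log units; that floor lies within the scatter), and that floor exists because the limit of > 48000 nM in this assay, at which 1 of the 3 values shown sits, is where compound 3 sits.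

Compound 4 `CCc1nnc(O)n2c(C)nc(C)c12` has not yet been measured. It differs from compound 2 by methyl in place of sec-butyl on an aromatic carbon. Among the measured compounds shown here, the one measured step that bears on this spot, a 1.7-fold higher number from compound 1 to compound 2 (0.24 log units; within the scatter), stayed within the scatter when tert-butyl changed to sec-butyl, so shortening further to methyl is expected to move the number little. The step is expected to be a 1.2-fold lower number from compound 2 to compound 4 (0.07 log units; within the scatter), with no clear direction beyond the scatter. Compound 4 is therefore estimated at 38000 nM, with a range from 15000 nM to 90000 nM.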

Compound 4, half-maximal inhibitory concentration: > 48000 nM
Compound 4 ended at the assay's limit; the forecaster's own chance of this, stated with the estimate: 30%; middle value at least 1.2-fold (0.10 log units) from the limit.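

In this assay compound 4 gives > 48000 nM, which is a limit of the assay and not a number. Its steps can therefore be read only as floors, an at least 1.0-fold higher number from compound 2 to compound 4 (0.02 log units; that floor lies within the scatter) and an at least 1.8-fold higher number from compound 1 to compound 4 (0.26 log units; that floor lies within the scatter), and since neither floor goes beyond the scatter, no real loss can be claimed against sec-butyl or tert-butyl. What is new is that methyl, on the carbon between two ring nitrogen atoms, brings no sign of stronger inhibition, and a second compound now gives no number to compare: the limit of > 48000 nM in this assay, at which 2 of the 4 values shown sit.

The compounds shown leave open how far past the limit compound 4 lies. They also leave open whether a phenyl ring, an amine or a carboxylic acid on this same carbon would give a number clearly apart from those of the alkyl groups.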